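Methyl on the Core of a Cytotoxicity Pair

This account rests on a few compounds, and the source may have more. Where it says the series, first, only, none or still open, it means among the compounds named here.

Measured so far:
compound 1, `O=c1ccn(C2C=C(CO)CO2)c(=O)[nH]1`: 33.3 ug/mL
compound 2, `Cc1cn(C2C=C(CO)CS2)c(=O)[nH]c1=O`: > 100 ug/mL

In a functional assay on HEL 299 cells (Homo sapiens) for cytotoxicity (a lower number here means that less compound is tolerated, a higher number that more compound is tolerated), compound 1 gives 33.3 ug/mL. Among the two values shown, compound 1 carries the only actual number; the remaining value is a limit rather than a number. For compound 2 the assay reports only (the limit of > 100 ug/mL in this assay, at which 1 of the 2 values shown sits), so no number is available for it. The unmeasured compound 3, `Cc1cn(C2C=C(CO)CO2)c(=O)[nH]c1=O`, differs from compound 1 by methyl in place of hydrogen on an aromatic carbon. Within the data shown here, no pair of measured compounds shows this change by itself, so its size cannot be read from the data. Compound 3 is expected to be tolerated somewhat more than compound 1, a step of a 1.8-fold higher number from compound 1 to compound 3 (0.26 log units; within the scatter), which lies close to the usual scatter. For compound 3 the estimated half-maximal cytotoxic concentration is 60 ug/mL, with a range from 25 ug/mL to 150 ug/mL, and a real chance that the assay returns only a limit.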

Compound 3, half-maximal cytotoxic concentration: > 100 ug/mL
Compound 3: only a limit was reported (the forecaster's own chance of this, stated with the estimate: 40%); at least 1.6-fold (0.22 log units) between middle value and limit.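

Among these compounds, for the first time this change stands alone: with the rest of compound 1 kept, methyl in place of hydrogen on an aromatic carbon gives an at least 3.0-fold higher number from compound 1 to compound 3 (0.47 log units; beyond the scatter) in this assay. A single added carbon at this position of the six-membered aromatic ring is thus enough to move the result beyond the scatter, towards more compound being tolerated. The result for compound 3 is a limit and not a number, so the step gives only the smallest size the change can have: the limit of > 100 ug/mL in this assay, at which 2 of the 3 values shown sit.

From the compounds shown here alone, the full size of the methyl step stays open, as does whether a longer chain such as ethyl, a chlorine atom or an amine at this position would act in the same direction. Compound 2 and compound 3 differ in one place, but both return only a limit, so that change cannot be read.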